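The source may report more compounds than this note shows. Statements on the series, on what has been measured and on what is new or still open speak of the compounds shown alone.

In a functional assay on Caco-2 cells (Homo sapiens) for antiproliferative activity, with a stated time of 48 h (on this read-out higher numbers stand for weaker inhibition and lower numbers for stronger inhibition), compound 1 (`CCN(CC)c1ccc(-c2cccc(OC)c2)nn1`) stands at > 25000 nM, which is a limit of the assay and not a number. Compound 2 (`COc1ccc(Nc2ccc(-c3ccccc3)nn2)cc1`) gives 50000 nM. Compound 3 (`CCN(CC)c1ccc(-c2cccc(Cl)c2)nn1`) carries chloro in place of methoxy on an aromatic carbon, meta to a large group (chloro in place of methoxy on an aromatic carbon). Within the data shown here, no measured step covers this change, so no shift beyond the scatter is expected in either direction in this assay. The expected step is small, with a step that the limit leaves unreadable from compound 1 to compound 3 as the estimate. Compound 3 is expected at 40000 nM, with an estimated range of 15000 nM to 100000 nM.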

Compound 3, half-maximal inhibitory concentration: > 25000 nM
Compound 3: no number, only a limit; the forecaster's own chance of this, stated with the estimate: 55%; the middle value does not contradict the limit.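

No step can be read from compound 1 to compound 3 in this assay, because both stand at a limit and not at a number: the limit of > 25000 nM in this assay, at which 2 of the 3 values shown sit.

The compounds shown leave open whether chloro in place of methoxy changes the antiproliferative activity at all.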